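A few compounds are considered here, and "the series" means these few. Any claim that something is new, unique, unknown or untested is made for them only; others in the source may bear on it.

Compound 1 `C[C@@H](Oc1cc(C(=O)N(C)C)ccc1Nc1nc(O[C@H]2CC[C@@](C)(O)CC2)c2c(Cl)c[nH]c2n1)C(F)(F)F` gives 65% in an ADME assay on S9 fraction from liver (Homo sapiens) for metabolic stability, with a stated time of 60 min; a higher number here means that more of the compound is left, a lower number that less of the compound is left
Compound 2 `COc1cc(N2CCN(C3COC3)CC2)ccc1Nc1nc(O[C@H]2CCOC(C)(C)C2)c2cc[nH]c2n1` gives 85% in this assay

Of these two, compound 2 stands highest with 85% in this assay and compound 1 lies lower, by a gap beyond the scatter. Compound 3 `COc1cc(N2CCN(C(=O)CO)CC2)ccc1Nc1nc(O[C@H]2CCOC(C)(C)C2)c2cc[nH]c2n1` has not yet been measured. It keeps the rest of compound 2 and differs in one place: (hydroxymethyl)carbonyl in place of oxetan-3-yl on an amine nitrogen in a ring with (hydroxymethyl)carbonyl in place of oxetan-3-yl on an amine nitrogen in a ring. Going by the values given here, no measured pair shows this change, so the expectation starts from compound 2 at 85% and stays close to it. The expected step is small, a number 5 percentage points lower from compound 2 to compound 3 (within the scatter) downward and not beyond the scatter. For compound 3 the estimated value is 80% with an expected range from 62% to 94% in this assay when it is measured.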

Compound 3, percent of the compound remaining: 79%
Compound 3: middle estimate off by 1 percentage points, on the high side; the range from low to high includes it.
By their numbers in this assay, from the lowest: compound 1; then compounds 3 and 2 (each within the scatter of the next).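

This first pair at this position shows that, in this assay, 4-((hydroxymethyl)carbonyl)piperazin-1-yl and 4-(oxetan-3-yl)piperazin-1-yl cannot be told apart, with a number 6 percentage points lower from compound 2 to compound 3 (within the scatter). On an amine nitrogen in a ring, the four-membered ring with its oxygen can therefore give way to an open group carrying a carbonyl and a hydrogen-bond donor, with no step beyond the scatter on this core. Nothing measured here says why the two groups read alike.

The compounds shown leave open whether a different group on the same ring nitrogen, such as a plain methyl group, an acetyl group or a carboxylic acid, would read alike as well. They also leave open whether this exchange gives the same result on any other core, since it rests on a single pair.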